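The compounds below may be only part of what the source reports. "The series", "measured", "known", "first", "only" and "open" are said of these compounds alone.

Working notes on the series. Compound 1 `ClCc1ccc(Cn2cnc3c(Cl)ncnc32)cc1` gives 57500 nM in a functional assay on BT-549 cells (Homo sapiens) for cytotoxicity, read by sulforhodamine B assay, with a stated time of 48 h (on this read-out higher numbers stand for lower toxicity in this test and lower numbers for higher toxicity in this test), the highest of the two numbers recorded. Among the compounds with values here, compound 2 `ClCc1ccccc1Cn1cnc2ncnc(Cl)c21` gives 25100 nM in this assay, a lower number than compound 1, a gap beyond the scatter; the two compounds differ in more than one place, so no single step is drawn between them. Compound 3 `ClCc1ccc(Cn2cnc3c(Cl)nc(Cl)nc32)cc1` is not yet measured and differs from compound 1 by chloro in place of hydrogen on an aromatic carbon. Within the data shown here, with no measured step on this change, the expectation for the step of a 1.3-fold lower number from compound 1 to compound 3 (0.11 log units; within the scatter) is no shift beyond the scatter, either direction possible. Compound 3 is estimated at 45000 nM, within 18000 nM to 110000 nM.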

Compound 3, concentration lethal to 50% of the cells: 56200 nM
Beside the measured number, compound 3's estimate is 1.2-fold (0.10 log units) below it; the range from low to high includes it.
By their numbers in this assay, from the lowest: compound 2; then compounds 3 and 1 (each within the scatter of the next).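

In this assay, chloro in place of hydrogen on an aromatic carbon, between two ring nitrogen atoms, gives a 1.0-fold lower number from compound 1 to compound 3 (0.01 log units; within the scatter), the first single-place step measured in the series. At this position, chloro and hydrogen therefore cannot be told apart in this read-out. Nothing available on the compounds accounts for this result.

As far as these compounds go, whether an amine or a methoxy group at this position would also stay within the scatter remains open. Also open, from the compounds shown here alone, is whether the same chloro change would give a comparable step on compound 2.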